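From compound 1 to compound 3: fluoro for methyl

The source may report more compounds than this note shows. Statements on the series, on what has been measured and on what is new or still open speak of the compounds shown alone.

Measured in a functional assay on HeLa cells (Homo sapiens) for cytotoxicity, read by MTT assay, with a stated time of 24 h; on this read-out lower numbers stand for stronger inhibition and higher numbers for weaker inhibition:
compound 1 `Cc1ccc(Cc2cn3cc(Cl)ccc3nc2=O)cc1`: > 1000000 nM
compound 2 `O=c1nc2ccc(Br)cn2cc1Cc1ccc(Cl)cc1`: > 1000000 nM

The reading of compound 1, > 1000000 nM, is a limit of the assay and not a number. The reading of compound 2, > 1000000 nM, is likewise a limit. Among the measured compounds shown here, the series so far stands at the limit of > 1000000 nM in this assay, at which 2 of the 2 values shown sit. Compound 1 therefore has a bound rather than a measured potency, and the two compounds cannot be ranked.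

The next compound is compound 3 `O=c1nc2ccc(Cl)cn2cc1Cc1ccc(F)cc1`. It has fluoro in place of methyl on an aromatic carbon, on a six-membered aromatic ring of carbon only, para to a large group (fluoro in place of methyl on an aromatic carbon). For the measured compounds named here, the series offers no measured step between two compounds, so the size of this change in this assay has no direct precedent. No step beyond the scatter is expected, and compound 3 is expected to stay near the same limit, because compound 1 reads > 1000000 nM. The expected step is a number no higher from compound 1 to compound 3 (the limit leaves the size open). Compound 3 is estimated at 1000000 nM, with an expected range from 400000 nM to 2500000 nM.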

Compound 3, half-maximal inhibitory concentration: > 1000000 nM
Compound 3: only a limit was reported; the forecaster's own chance of this, stated with the estimate: 85%; the middle value sits exactly at the limit.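

In this assay, compound 1 and compound 3 both read as limits and not as numbers, so no step can be read between them: the limit of > 1000000 nM in this assay, at which 3 of the 3 values shown sit.

The compounds shown leave open whether any change to the shared core would give a measured half-maximal inhibitory concentration instead of a limit.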